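Second Chloro on the Benzyl Ring of a Pyrazole Amide

The source may hold more compounds than are shown below. What is called first, only, known or untested is meant among the compounds shown, and "the series" means these compounds.

Measured compounds:
compound 1, `COc1ccc(-c2nn(-c3ccccc3)cc2C(=O)NOCc2ccccc2F)cc1`: 24600 nM
compound 2, `COc1ccc(-c2nn(-c3ccccc3)cc2C(=O)NOCc2ccccc2Cl)cc1`: 586000 nM
Not yet measured: compound 3, `COc1ccc(-c2nn(-c3ccccc3)cc2C(=O)NOCc2ccc(Cl)cc2Cl)cc1`

Going by the values given here, in an ADME assay on HEK-293T cells (Homo sapiens) for antiproliferative activity, read by MTT assay, with a stated time of 48 h, in the presence of a further agent that is not named here (a higher number here means that more compound is tolerated, a lower number that less compound is tolerated), compound 2 holds the highest number of the two measured so far. Among the compounds with values here, its nearest neighbour is compound 1, and the only measured step, a 24-fold higher number from compound 1 to compound 2 (1.38 log units; beyond the scatter), lies well beyond the scatter. Compound 3 differs from compound 2 by chloro in place of hydrogen on an aromatic carbon. Within the data shown here, no measured step adds a chloro in place of hydrogen; the single step known here swaps one halogen for another, so it bears on this change only loosely and gives no direction of its own. With nothing closer to lean on, the expectation is a step of a 1.5-fold lower number from compound 2 to compound 3 (0.17 log units; within the scatter) from compound 2 to compound 3, most likely within the scatter and with a wide band of uncertainty around it. Compound 3 is therefore estimated at 400000 nM in this assay, with a range from 100000 nM to 1500000 nM.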

Compound 3, half-maximal cytotoxic concentration: 545000 nM
Estimate against measurement, compound 3: 1.4-fold (0.13 log units) below, within the range that was stated.
By their numbers in this assay, from the lowest: compound 1; then compounds 3 and 2 (each within the scatter of the next).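

In this assay the chloro that enters para to a large group and meta to the existing chloro gives a 1.1-fold lower number from compound 2 to compound 3 (0.03 log units; within the scatter), so the change from 2-chlorobenzyl to 2,4-dichlorobenzyl cannot be told apart from repeat variation. Going by these compounds alone, this is the first information on this place on the ring, which carried only hydrogen in the earlier compounds, and here a chloro is accepted without a measurable shift in the number. The large gap to the fluoro compound also persists with the second chloro present, at a 22-fold higher number from compound 1 to compound 3 (1.35 log units; beyond the scatter), so compounds 2 and 3 both stand well clear of compound 1, while no supporting evidence is available to explain either result.

Going by these compounds, it remains open whether a methoxy group, an amine or a carboxylic acid at this place on the ring would also leave the number unchanged, or whether the silence of this position is particular to chloro. Also open, on these data alone, is whether a chloro at the same place would be equally without effect on the 2-fluorobenzyl group of compound 1, where the starting number is much lower.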